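The source may report more compounds than this note shows. Statements on the series, on what has been measured and on what is new or still open speak of the compounds shown alone.

In an ADME assay on CHO cells (Cricetulus griseus) for cytotoxicity, read by MTT assay (on this read-out lower numbers stand for higher toxicity in this test and higher numbers for lower toxicity in this test), compound 1 (`Fc1ccc(Nc2cc3[nH]c(Nc4cc(N5CCNCC5)ccn4)nc3cn2)cc1C(F)(F)F`) gives 31000 nM and compound 2 (`Fc1ccc(Nc2cc3[nH]c(Nc4ccc(N5CCNCC5)cn4)nc3cn2)cc1F`) gives 33000 nM, two values within the scatter of each other. Compound 3 (`Fc1ccc(Nc2cc3[nH]c(Nc4ccc(N5CCN(CC6CC6)CC5)cn4)nc3cn2)cc1F`) gives 1200 nM, a clearly lower number than either.

Compound 4 (`C[C@@H]1CN(C(=O)c2ccnc(Nc3nc4cnc(Nc5ccc(F)c(C(F)(F)F)c5)cc4[nH]3)c2)C[C@H](C)N1`) differs from compound 1 by (3,5-dimethylpiperazin-1-yl)carbonyl in place of piperazin-1-yl on an aromatic carbon, opposite the ring nitrogen: (3,5-dimethylpiperazin-1-yl)carbonyl in place of piperazin-1-yl on an aromatic carbon.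

For the measured compounds named here, only one measured step bears on this change, and only loosely: a 28-fold lower number from compound 2 to compound 3 (1.44 log units; beyond the scatter), a large step for cyclopropylmethyl in place of hydrogen on an amine nitrogen in a ring. No cyclopropylmethyl enters in compound 4, so a step of that size is not carried over. Going by the values given here, no measured step covers the carbonyl or the two methyl groups of the entering group, which leaves the direction uncertain.

A small step towards a lower number is expected in this assay, likely within the scatter: the estimated change is a 1.6-fold lower number from compound 1 to compound 4 (0.19 log units; within the scatter). The estimate for compound 4 is 20000 nM, with an expected range of 6000 nM to 60000 nM.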

Compound 4, half-maximal cytotoxic concentration: 29000 nM
The estimate for compound 4 lay 1.5-fold (0.16 log units) below the measured number, within the range that was stated.
By their numbers in this assay, from the lowest: compound 3; then compounds 4, 1 and 2 (each within the scatter of the next).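

In this assay, placing (3,5-dimethylpiperazin-1-yl)carbonyl in place of piperazin-1-yl on this aromatic carbon, opposite the ring nitrogen, gives a 1.1-fold lower number from compound 1 to compound 4 (0.03 log units; within the scatter), so this larger group leaves the read-out level with that of compound 1. At this position, then, the carbonyl and the two methyl groups entering together do not produce a step of the size of a 28-fold lower number from compound 2 to compound 3 (1.44 log units; beyond the scatter), which belongs to a different change on a different pair. No measurement at hand explains why the read-out holds across this change.

On these data alone, the carbonyl and the two methyl groups enter as one change, so their separate contributions stay open. Also open, as far as these compounds go, is how an acidic replacement such as a carboxylic acid, or a morpholine ring, would read at this position.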